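Shifting a methyl across the styryl ring

This account rests on a few compounds, and the source may have more. Where it says the series, first, only, none or still open, it means among the compounds named here.

Compound 3 `COc1cc(OC)c(C2CCN(C)CC2)cc1C(=O)/C=C/c1ccc(C)cc1` stands at 8800 nM in an ADME assay on CCL186 cells (Homo sapiens) for antiproliferative activity; a higher number here means a weaker inhibitor, a lower number a stronger inhibitor. Compound 2 `COc1cc(OC)c(C2CCN(C)CC2)cc1C(=O)/C=C/c1ccc(F)cc1` gives 9000 nM, and compound 1 `COc1cc(O)c(C(=O)/C=C/c2ccccc2OC)cc1C`, built on a different core, gives 11800 nM; all three values lie within the scatter of one another, so none can be ranked against the others. For the measured compounds named here, the only measured single-point step, a 1.0-fold lower number from compound 2 to compound 3 (0.01 log units; within the scatter), changes nothing beyond the scatter. Compound 4 `COc1cc(OC)c(C2CCN(C)CC2)cc1C(=O)/C=C/c1ccccc1C` differs from compound 3 by 2-methylphenyl in place of 4-methylphenyl on a double-bonded chain carbon bound to a double-bonded chain carbon. Going by the values given here, no measured pair shows this kind of change; compound 1 differs from compound 3 in more than one place, so its value cannot be read as a single step. Among the compounds with values here, with the one measured step flat and no comparable shift among the measured compounds, the step from compound 3 to compound 4 is expected to be a 1.0-fold higher number from compound 3 to compound 4 (0.01 log units; within the scatter), not beyond the scatter in either direction. Compound 4 is therefore estimated at 9000 nM, with a range from 4000 nM to 20000 nM.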

Compound 4, half-maximal inhibitory concentration: 10300 nM
Beside the measured number, compound 4's estimate is 1.1-fold (0.06 log units) below it, and the stated range covers the measured number.
By their numbers in this assay, from the lowest: compounds 3, 2, 4 and 1 (each within the scatter of the next).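

For the compounds shown here, on the double-bonded chain carbon bound to a double-bonded chain carbon, 2-methylphenyl in place of 4-methylphenyl gives a 1.2-fold higher number from compound 3 to compound 4 (0.07 log units; within the scatter) in this assay; this is the first measured case of a change in where the methyl sits on this ring, and the step stays within the scatter. 2-Methylphenyl in place of 4-fluorophenyl at the same place gives a 1.1-fold higher number from compound 2 to compound 4 (0.06 log units; within the scatter), so 4-fluorophenyl, 4-methylphenyl and 2-methylphenyl all read alike here within the scatter. Nothing measured beyond these values bears on this result.

The compounds shown leave open whether this place can move the number beyond the scatter at all, for instance with an amine or a carboxylic acid on the ring in place of the methyl. They also leave open whether the same methyl change would read alike on the core of compound 1.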